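The compounds below may be only part of what the source reports. "The series", "measured", "known", "first", "only" and "open" are said of these compounds alone.

Compound 1 `CCc1c(F)c(N)c2c(=O)cc(-c3ccc(N)c(F)c3)oc2c1F`: > 100000 nM
Compound 2 `CCCCc1c(F)c(N)c2c(=O)cc(-c3ccc(N)c(F)c3)oc2c1F`: > 100000 nM
Compound 3 `Nc1ccc(-c2cc(=O)c3c(N)c(F)c(Br)c(F)c3o2)cc1F`: > 100000 nM

In a functional assay on HeLa cells (Homo sapiens) for cytotoxicity, read by neutral red uptake, with a stated time of 3 days (on this read-out higher numbers stand for weaker inhibition and lower numbers for stronger inhibition), compound 3 gives > 100000 nM, which is a limit of the assay and not a number. It stands with the other two compounds, at the limit of > 100000 nM in this assay, at which 3 of the 3 values shown sit.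

Compound 4 `COc1c(F)c(N)c2c(=O)cc(-c3ccc(N)c(F)c3)oc2c1F` carries methoxy in place of bromo on an aromatic carbon, ortho to two fluoro groups: methoxy in place of bromo on an aromatic carbon.

The measured steps that bear on this change all alter the group on that same carbon: a step that the two limits leave unreadable from compound 1 to compound 3, a step that the two limits leave unreadable from compound 2 to compound 3 and a step that the two limits leave unreadable from compound 1 to compound 2. None of them has a readable size, so they set no number for the new step. Compounds 1, 2 and 3 carry ethyl, butyl and bromo on this carbon and all sit at the limit of > 100000 nM in this assay, at which 3 of the 3 values shown sit, so no step beyond the scatter is expected in this assay, in either direction. The expected step is a number no higher from compound 3 to compound 4 (the limit leaves the size open). The estimate for compound 4 is 100000 nM, with an expected range of 40000 nM to 200000 nM.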

Compound 4, half-maximal inhibitory concentration: 34000 nM
For compound 4 the middle estimate is 2.9-fold (0.47 log units) above the measured one; the measured number lies below the stated range.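

In this assay the group on this carbon proves able to move the read-out: methoxy in place of bromo gives an at least 2.9-fold lower number from compound 3 to compound 4 (0.46 log units; beyond the scatter) and in place of butyl gives an at least 2.9-fold lower number from compound 2 to compound 4 (0.46 log units; beyond the scatter) and in place of ethyl gives an at least 2.9-fold lower number from compound 1 to compound 4 (0.46 log units; beyond the scatter) while the rest of the molecule stays the same. Within the data shown here, the steps among compounds 1, 2 and 3 cannot be read, so these are the first steps at this position that show a change beyond the scatter. Among these compounds, compound 4 is also the only one of the four compounds with a true number rather than a limit: the limit of > 100000 nM in this assay, at which 3 of the 4 values shown sit.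

On these data alone, each new step starts from a limit, so its full size stays open. As far as these compounds go, whether a hydroxy, an ethoxy or an amine on this carbon would also give a measurable number also stays open.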